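Two Flipped Stereocentres on a Short-Lived Compound

This account rests on a few compounds, and the source may have more. Where it says the series, first, only, none or still open, it means among the compounds named here.

Among the compounds with values here, in an ADME assay on liver (Mus musculus, strain C57BL/6) for metabolic stability, read by HPLC, with a stated time of 12 h (on this read-out higher numbers stand for a longer-lived compound and lower numbers for a shorter-lived compound), compound 2 `O=C(O)[C@H](CO)NC(=O)[C@@H]1C[C@H](O)CN1` gives 0.51 h, the only true number so far. Compound 1 `O=C(O)[C@H](CO)NC(=O)[C@H]1C[C@H](O)CN1` reads > 12 h, which is a limit of the assay and not a number.

Compound 3 `O=C(N[C@H](CO)C(=O)O)[C@@H]1C[C@@H](O)CN1` has the same atoms and bonds as compound 2, and only its three-dimensional arrangement changes: the two compounds have the same atoms and bonds and differ only in configuration as drawn: 2 of 3 stereo elements differ; a stereocentre at a saturated chain carbon is drawn S in compound 2 and R in compound 3; a stereocentre at a saturated ring carbon is drawn S in compound 2 and R in compound 3.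

Within the data shown here, only one measured step bears on this. It is large and lies beyond the scatter: an at least 23-fold lower number from compound 1 to compound 2 (1.37 log units; beyond the scatter). It came with the fact that compounds 1 and 2 differ only in the configuration as drawn, so a change of configuration alone can matter greatly here. That step took a ring carbon from R to S, whereas compound 3 takes a ring carbon from S to R, so a longer half-life is expected, though one step is a thin guide.

The expected change is a 5.9-fold higher number from compound 2 to compound 3 (0.77 log units; beyond the scatter). For compound 3 the estimated half-life is 3 h, with an expected range from 0.6 h to 12 h.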

Compound 3, half-life in the Mus musculus assay: 0.32 h
Compound 3: the middle estimate sits 9.4-fold (0.97 log units) above what was measured; measured number below the stated range.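

In the Mus musculus assay, inverting a chain stereocentre and a ring stereocentre together gives a change that stays inside the usual scatter (a 1.6-fold lower number from compound 2 to compound 3 (0.20 log units; within the scatter)), so these two stereoisomers cannot be told apart on this read-out. In the Mus musculus assay, the mirror image of compound 1 does not keep its long half-life (an at least 37-fold lower number from compound 1 to compound 3 (1.57 log units; beyond the scatter)), and this large gap comes with no change in atoms or bonds: the fact that compounds 1 and 3 differ only in the configuration as drawn. In the Mus musculus assay, compound 1 gives > 12 h, which is a limit of the assay and not a number.

In a physicochemical assay for metabolic stability, read by HPLC, with a stated time of 12 h, at pH 4.5 (a higher number here means that the compound lasts longer, a lower number that the compound disappears faster), compound 2 gives > 12 h, which is a limit of the assay and not a number. In the physicochemical assay, compound 3 gives > 12 h, which is likewise a limit of the assay and not a number. Within the data shown here, in the physicochemical assay, no step between the compounds can be read: the limit of > 12 h in the physicochemical assay, at which 2 of the 2 values shown sit. Going by these compounds, it remains open how the half-life in the Mus musculus assay would respond to a methyl ester in place of the carboxylic acid, or to a fluorine in place of the ring hydroxyl.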